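This account rests on a few compounds, and the source may have more. Where it says the series, first, only, none or still open, it means among the compounds named here.

In an ADME assay on THP-1 cells (Homo sapiens) for cytotoxicity, read by flow cytometry and propidium iodide staining, with a stated time of 72 h (on this read-out higher numbers stand for weaker inhibition and lower numbers for stronger inhibition), compound 1 `Cc1nc(CS(=O)(=O)c2ccc(Cl)cc2)c([N+](=O)[O-])n1C` gives 68000 nM, and compound 2 `Cc1nc(CS(=O)(=O)c2ccccc2)c([N+](=O)[O-])n1CC(C)O` gives 418000 nM. Compound 3 `Cc1ccc(S(=O)(=O)Cc2nc(C)n(CC(C)O)c2[N+](=O)[O-])cc1` gives > 707000 nM, which is a limit and not a number. Compound 4 `Cc1nc(CS(=O)(=O)c2ccc(Cl)cc2)c([N+](=O)[O-])n1CC(C)O` keeps the frame of compound 3 and makes one change, chloro in place of methyl on an aromatic carbon. Among the measured compounds shown here, the one measured step at this position, an at least 1.6-fold higher number from compound 2 to compound 3 (0.22 log units; that floor lies within the scatter), says little about size. For the measured compounds named here, compound 1, the only measured compound carrying this chloro group, gives 68000 nM, although it also differs elsewhere. On that evidence, the expected change is an at least 3.2-fold lower number from compound 3 to compound 4 (0.50 log units; beyond the scatter), toward a lower number and so stronger inhibition. Compound 4 is expected at 220000 nM, with an estimated range of 70000 nM to 600000 nM.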

Compound 4, half-maximal inhibitory concentration: > 688000 nM
Compound 4: a limit, no number; the forecaster's own chance of this, stated with the estimate: 15%; middle value at least 3.1-fold (0.49 log units) from the limit.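

Compound 4 stands at a limit, not a number, as does compound 3, so the step between them cannot be read. Chloro on the ring therefore does not by itself bring the low value seen for compound 1: with hydrogen as the comparison there is an at least 1.6-fold higher number from compound 2 to compound 4 (0.21 log units; that floor lies within the scatter), and that is only a floor. With chloro held constant, the change on the chain gives an at least 10-fold higher number from compound 1 to compound 4 (1.00 log units; beyond the scatter), so in this pair the chain change alone goes with the higher number. On these data alone, whether chloro matters with the chain of compound 1 stays open. So does what an amine in place of the hydroxyl on the chain would do.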